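A methyl group added to the aniline ring of compound 1

This account rests on a few compounds, and the source may have more. Where it says the series, first, only, none or still open, it means among the compounds named here.

Compound 1 `CCOC(=O)c1c(C)oc2ncnc(Nc3ccccc3)c12` is a fused bicyclic ester bearing a plain phenylamino group. Going by the values given here, in a functional assay on MCF7 cells (Homo sapiens) for cytotoxicity, read by MTT assay, with a stated time of 72 h (on this read-out lower numbers stand for stronger inhibition and higher numbers for weaker inhibition), compound 1 gives 851000 nM, the highest of the three numbers known. Compound 2 `Cc1oc2ncnc(Nc3ccc(OCc4cccc(F)c4)c(Cl)c3)c2c1C(=O)O` gives 46000 nM in this assay, and compound 3 `Cc1oc2ncnc(Nc3cccc(Br)c3)c2c1CO` gives 11000 nM, so compound 1 stands beyond the scatter from both and is the weakest of the three. Compound 4 `CCOC(=O)c1c(C)oc2ncnc(Nc3cccc(C)c3)c12` differs from compound 1 by one change: methyl in place of hydrogen on an aromatic carbon, on an aromatic carbon of a six-membered aromatic ring of carbon only. Among the compounds with values here, no measured pair shows this change alone. Compound 4 is expected to move a 2.4-fold lower number from compound 1 to compound 4 (0.39 log units; beyond the scatter), a modest lowering, with an estimated value of 350000 nM and a range from 120000 nM to 1000000 nM.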

Compound 4, half-maximal inhibitory concentration: > 1000000 nM
Compound 4 was reported as a limit; the forecaster's own chance of this, stated with the estimate: 20%; middle value at least 2.8-fold (0.45 log units) away from the limit.
By their numbers in this assay, from the lowest: compound 3; then compound 2; then compound 1. At a limit, above all of these: compound 4.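

In this assay compound 4 gives a limit and not a number, > 1000000 nM. Methyl in place of hydrogen at this position, on the aromatic carbon meta to a large group, brought no lowering of the number; the step is an at least 1.1-fold higher number from compound 1 to compound 4 (0.07 log units; that floor lies within the scatter), so its true size is not fixed. This is the only reading of its kind among the compounds shown: the limit of > 1000000 nM in this assay, at which 1 of the 4 values shown sits.

On these data alone, it remains open whether an amine, a methoxy group or a carboxylic acid at this same position would lower the number. As far as these compounds go, it also remains open whether methyl on another carbon of this ring would read differently.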